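The source may report more compounds than this note shows. Statements on the series, on what has been measured and on what is new or still open speak of the compounds shown alone.

Working notes on the series. Among the measured compounds shown here, the three measured members are compound 1 `Cc1nnc(Sc2c(C)oc3ccccc3c2=O)o1`, compound 2 `Cc1nnc(SCc2coc3ccc(Cl)cc3c2=O)o1` and compound 3 `Cc1nnc(SCc2coc3ccc(Cl)cc3c2=O)s1`; the member still to be measured is compound 4 `Cc1nnc(SCc2coc3ccccc3c2=O)o1`. In a functional assay on LM7 cells (Homo sapiens) for cytotoxicity, read by MTT assay, with a stated time of 72 h (on this read-out lower numbers stand for stronger inhibition and higher numbers for weaker inhibition), compound 1 gives > 50000 nM, which is a limit of the assay rather than a number (the limit of > 50000 nM in this assay, at which 1 of the 3 values shown sits). In this assay compound 2 gives 8700 nM, the highest of the two numbers shown, and compound 3 gives 7600 nM. For the measured compounds named here, the only one-place step measured, a 1.1-fold lower number from compound 2 to compound 3 (0.06 log units; within the scatter), is within the scatter and concerns the heterocycle on the sulfur, not the chlorinated ring.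

The step under study is hydrogen in place of chloro on an aromatic carbon. Compound 1 also carries no chloro, but it differs from compound 2 at more than one place, so its limit cannot be tied to the chloro alone. Going by the values given here, no measured step bears on the change from compound 2 to compound 4, and the expectation therefore rests on the value of compound 2 as the anchor: a 1.7-fold higher number from compound 2 to compound 4 (0.24 log units; within the scatter) is estimated to be small, with a somewhat higher number held as the more likely direction. Compound 4 is expected to give 15000 nM in this assay, within a range from 6000 nM to 50000 nM.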

Compound 4, half-maximal inhibitory concentration: 3500 nM
Compound 4: the middle estimate sits 4.3-fold (0.63 log units) above what was measured, and the stated range ends above it.
By their numbers in this assay, from the lowest: compound 4; then compounds 3 and 2 (each within the scatter of the next). At a limit, above all of these: compound 1.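

Hydrogen in place of chloro on an aromatic carbon, meta to a fused ring and para to a fused ring, gives a 2.5-fold lower number from compound 2 to compound 4 (0.40 log units; beyond the scatter) in this assay and is the first one-place step in the series to lie beyond the scatter. The chloro at this position is therefore not needed for a measured number in this read-out, and losing it moves the number modestly towards stronger inhibition. The only other one-place step, a 1.1-fold lower number from compound 2 to compound 3 (0.06 log units; within the scatter) and so within the scatter, concerns the heterocycle on the sulfur, which leaves the chloro position as the one place shown where a single change moves the number.

Still open, as far as these compounds go, is how other groups at this position, such as fluoro, methoxy or an amine, would compare with hydrogen and chloro, and whether the same change holds with the 5-methyl-1,3,4-thiadiazol-2-yl group on the sulfur. Nothing at hand bears on why this step goes in this direction.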